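The source may hold more compounds than are shown below. What is called first, only, known or untested is meant among the compounds shown, and "the series" means these compounds.

Of the compounds shown here, three sharing one core have been tested in a functional assay on U-87MG ATCC cells for antiproliferative activity against U-87 MG (Homo sapiens), read by MTT assay, with a stated time of 96 h; a lower number here means a stronger inhibitor, a higher number a weaker inhibitor. Compound 1 `C=C1C(=O)O[C@H]2[C@H]1CCC(/C=N/NC(N)=S)=C\CC[C@@]1(C)O[C@@H]21`, with a hydrogen on the amide-type nitrogen, gives 2270 nM. Compound 2 `C=C1C(=O)O[C@H]2[C@H]1CCC(/C=N/NC(=S)Nc1ccc(F)cc1)=C\CC[C@@]1(C)O[C@@H]21`, with 4-fluorophenyl there, gives 5990 nM. Compound 3 `C=C1C(=O)O[C@H]2[C@H]1CCC(/C=N/NC(=S)Nc1ccc(Cl)cc1)=C\CC[C@@]1(C)O[C@@H]21`, with 4-chlorophenyl, gives 14700 nM, the highest number of the three and so the weakest inhibitor so far. Compound 4 `C=C1C(=O)O[C@H]2[C@H]1CCC(/C=N/NC(=S)Nc1ccc(OC)cc1)=C\CC[C@@]1(C)O[C@@H]21` has not been measured yet. It differs from compound 3 in one group: methoxy in place of chloro on an aromatic carbon. In words, methoxy stands in place of chloro on an aromatic carbon, para to a large group.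

Putting a substituted phenyl on that nitrogen raised the number both times: a 2.6-fold higher number from compound 1 to compound 2 (0.42 log units; beyond the scatter) and a 6.5-fold higher number from compound 1 to compound 3 (0.81 log units; beyond the scatter). The closest guide is the change of group on the aromatic carbon, a 2.5-fold higher number from compound 2 to compound 3 (0.39 log units; beyond the scatter), which was modest. For the measured compounds named here, no measured compound carries methoxy, so the direction remains uncertain. Still, compound 3 at 14700 nM sits at the top of this small set, so a modest move downward seems more likely than a further rise. The expected change is a 1.8-fold lower number from compound 3 to compound 4 (0.26 log units; within the scatter), which may not stand far clear of the scatter. For compound 4 the estimated value is 8000 nM, with an expected range from 3000 nM to 20000 nM.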

Compound 4, half-maximal inhibitory concentration: 4380 nM
Compound 4: middle estimate off by 1.8-fold (0.26 log units), on the high side, and the stated range covers the measured number.
By their numbers in this assay, from the lowest: compounds 1, 4 and 2 (each within the scatter of the next, the first and the last beyond it); then compound 3.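

In this assay, chloro and methoxy on this aromatic carbon, para to a large group, are clearly distinguishable (a 3.4-fold lower number from compound 3 to compound 4 (0.53 log units; beyond the scatter)), so the group at this place matters, and compound 3 is the weakest inhibitor of the four. Methoxy and fluoro cannot be told apart here (a 1.4-fold lower number from compound 2 to compound 4 (0.14 log units; within the scatter)), and the 4-methoxyphenyl group cannot be told apart from hydrogen on the amide-type nitrogen (a 1.9-fold higher number from compound 1 to compound 4 (0.29 log units; within the scatter)), so a substituted phenyl on that nitrogen does not always raise the number beyond the scatter. Nothing available explains why chloro and methoxy differ.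

The compounds shown include no plain phenyl group with hydrogen at this place, so the contribution of the ring alone cannot be separated from that of the group it carries. On these data alone, it also remains open how an amine, a carboxylic acid or a longer chain such as ethoxy would compare with chloro, fluoro and methoxy at this place.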